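The source may hold more compounds than are shown below. What is called first, only, known or untested is meant among the compounds shown, and "the series" means these compounds.

Working notes on the series.

Three compounds have numbers in an assay on isolated protein for inhibition of Aromatase (Homo sapiens), read by fluorescence, with a stated time of 30 min; on this read-out higher numbers stand for weaker inhibition and lower numbers for stronger inhibition. Compound 1 `NCCOc1ccc(/C(=C(\CCCl)c2ccccc2)c2ccc(O)cc2)cc1` gives 143 nM. Compound 2 `CCC/C(=C(/c1ccc(O)cc1)c1ccc(OCCN)cc1)c1ccccc1` gives 261 nM. Compound 3 `NCCOc1ccc(/C(=C/c2ccccc2)c2ccc(O)cc2)cc1` gives 6290 nM. On these numbers compound 2 stands second highest of three; its nearest neighbour is compound 1, and the step of a 1.8-fold higher number from compound 1 to compound 2 (0.26 log units; within the scatter) is within the scatter. Going by the values given here, compound 3, which lacks the saturated chain altogether, gives a far higher number than compound 2, so the chain appears to matter on what is seen so far, though only this one pair speaks to it.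

The change now considered is cyano in place of ethyl on a saturated chain carbon bound to a double-bonded chain carbon, giving compound 4 `N#CC/C(=C(/c1ccc(O)cc1)c1ccc(OCCN)cc1)c1ccccc1`. Among the compounds with values here, the only measured step at the chain, from compound 1 to compound 2, is within the scatter, and no measured pair puts a cyano group anywhere, so there is no direct precedent for this exchange. The chain is kept, which separates compound 4 from the case of compound 3. On that basis the expectation for compound 4 in this assay is a step of a 1.3-fold higher number from compound 2 to compound 4 (0.13 log units; within the scatter) that is small, possibly none beyond the scatter, leaning toward a somewhat higher number. Compound 4 is estimated at 350 nM, within a range from 90 nM to 1400 nM.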

Compound 4, half-maximal inhibitory concentration: 48.9 nM
The estimate for compound 4 lay 7.2-fold (0.85 log units) above the measured number; the whole stated range lies above it.
By their numbers in this assay, from the lowest: compound 4; then compounds 1 and 2 (each within the scatter of the next); then compound 3.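

In this assay, going by these compounds alone, the group at this place now makes a difference beyond the scatter: the exchange of ethyl for cyano gives a 5.3-fold lower number from compound 2 to compound 4 (0.73 log units; beyond the scatter), whereas the only earlier step at the chain, a 1.8-fold higher number from compound 1 to compound 2 (0.26 log units; within the scatter), did not. The exchange of chloromethyl for cyano points the same way, with a 2.9-fold lower number from compound 1 to compound 4 (0.47 log units; beyond the scatter), so compound 4 stands apart from two chain-bearing compounds whose numbers lie within the scatter of each other. Nothing at hand bears on what lies behind this shift.

The series leaves open whether other groups at this place, such as an amine, a carboxylic acid or a longer chain, would shift the number in the same direction. With a single nitrile among the compounds shown, no general pattern for that group can be stated.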